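This account rests on a few compounds, and the source may have more. Where it says the series, first, only, none or still open, it means among the compounds named here.

Notes on a small set of compounds measured in a functional assay on KG-1 cells (Homo sapiens) for cytotoxicity, read by luminescence and CellTiter-Glo, with a stated time of 3 days; a higher number here means a weaker inhibitor, a lower number a stronger inhibitor. Within the data shown here, compound 1 `O=C(Nc1cc(C(F)(F)F)cc(C(F)(F)F)c1)c1ccc(Cl)cc1O` is the only member with a numerical result: in this assay compound 1 gives 620 nM. Compound 2 `COc1cccc(C(=O)Nc2ccc(C#N)cc2)c1O` pairs a hydroxybenzamide carrying a methoxy group with a nitrile-bearing anilide. In this assay compound 2 reaches only the limit of > 10000 nM, not a number. Compound 3 `N#Cc1ccc2nc(-c3ccccc3O)[nH]c2c1` places the hydroxyphenyl on a different core, again with a nitrile. In this assay compound 3 likewise stops at the limit of > 10000 nM. Compound 2 therefore stands at the limit of > 10000 nM in this assay, at which 2 of the 3 values shown sit, shared with compound 3, while compound 1 alone lies inside the measured range. Among the measured compounds shown here, no two measured compounds differ in a single place, so no measured step is available.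

Compound 4 `N#Cc1ccc(NC(=O)c2cccc(Br)c2O)cc1` is the next analogue: bromo in place of methoxy on an aromatic carbon. For the measured compounds named here, compound 1, the one compound with a value of 620 nM, differs from compound 4 in several places and cannot anchor this step. A modest step toward stronger inhibition is expected from compound 2 to compound 4, an at least 2.0-fold lower number from compound 2 to compound 4 (0.30 log units; that floor lies within the scatter), with a result at the limit remaining nearly as likely. Compound 4 is accordingly estimated at 5000 nM, in a range from 1000 nM to 20000 nM.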

Compound 4, half-maximal inhibitory concentration: 3260 nM
Beside the measured number, compound 4's estimate is 1.5-fold (0.19 log units) above it; the range from low to high includes it.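

Among these compounds, this is the first readable step, and it shows that the position ortho to a hydroxy group is not silent in this assay: bromo in place of methoxy on an aromatic carbon gives an at least 3.0-fold lower number from compound 2 to compound 4 (0.48 log units; beyond the scatter). The nitrile-bearing anilide therefore also yields a numerical result, as compound 4 gives 3260 nM. The true size of the step remains unknown, and the printed figure is only a floor, because the methoxy compound stands at a limit and not at a number: the limit of > 10000 nM in this assay, at which 2 of the 4 values shown sit.

With a single replacement in view, the data cannot separate what is lost with the methoxy from what is gained with the bromo, and an amine or a carboxylic acid on the same aromatic carbon would show whether other groups also move the value at this position. From the compounds shown here alone, compound 1 and compound 3 each differ from compound 4 in more than one place, so steps to them cannot be read, and the contribution of the nitrile and of the rest of the anilide remains open.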